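Lengthening the acetyl chain of compound 2

The compounds below may be only part of what the source reports. "The series", "measured", "known", "first", "only" and "open" are said of these compounds alone.

In a functional assay on PC-3 cells (Homo sapiens) for antiproliferative activity, read by MTT assay, with a stated time of 72 h (a lower number here means a stronger inhibitor, a higher number a weaker inhibitor), compound 1 `CCC(=O)NNC(=O)c1csc2ncc(-c3ccc(OC)cc3)n12` gives 79800 nM, while compound 2 `CC(=O)NNC(=O)c1csc2ncc(-c3ccc(Br)cc3)n12` gives 12700 nM, the lower of the two numbers and so the stronger result. Compound 3 `CCC(=O)NNC(=O)c1csc2ncc(-c3ccc(Br)cc3)n12` differs from compound 2 in one place: methyl in place of hydrogen on a saturated chain carbon bound to a carbonyl carbon, turning acetyl into propanoyl (methyl in place of hydrogen on a saturated chain carbon bound to a carbonyl carbon). For the measured compounds named here, no measured pair shows this change alone, so only a small shift is expected in this assay, none beyond the scatter. The estimated change is a 1.1-fold higher number from compound 2 to compound 3 (0.04 log units; within the scatter). For compound 3 the estimated value is 14000 nM, with an expected range from 6000 nM to 35000 nM.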

Compound 3, half-maximal inhibitory concentration: 43700 nM
Compound 3: the middle estimate sits 3.1-fold (0.49 log units) below what was measured; the measured number lies above the stated range.
By their numbers in this assay, from the lowest: compound 2; then compounds 3 and 1 (each within the scatter of the next).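

In this assay, adding one methyl to turn acetyl into propanoyl gives a 3.4-fold higher number from compound 2 to compound 3 (0.54 log units; beyond the scatter), so this chain carbon is sensitive to even this small addition, at least with bromo on the aromatic ring. With propanoyl held fixed, bromo in place of methoxy on an aromatic carbon gives a 1.8-fold lower number from compound 1 to compound 3 (0.26 log units; within the scatter), so this swap shows no clear effect. No measurement here gives a reason for the loss from the added methyl. The compounds shown leave open whether a longer chain such as butanoyl would weaken the result further, and whether an amine on this chain would fare differently.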